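Series notes: amine variation on the side chain of compound 2

The source may report more compounds than this note shows. Statements on the series, on what has been measured and on what is new or still open speak of the compounds shown alone.

Measured compounds:
compound 1 `COc1ccc(-c2cc(-c3ccccc3)no2)c(OCCCN2CCCCC2)c1`, in a functional assay on the whole organism (blood, strain Charles Foster/Wistar albino) with Rattus norvegicus as the target, with a stated time of 30 min, at a dose of 100 mg/kg by the oral route (on this read-out lower numbers stand for less inhibition and higher numbers for more inhibition at the one dose given (going by the name of the read-out)), compound 1 gives 20.8%.
compound 2 `COc1ccc(-c2cc(-c3ccccc3)no2)c(OCC(O)CN2CCCCC2)c1`, in this assay compound 2 gives 17%.
compound 3 `COc1ccc(-c2cc(-c3ccccc3)no2)c(O)c1`, in this assay compound 3 gives 9.8%.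

Compound 2 stands second of the three numbers; both a number 3.8 percentage points lower from compound 1 to compound 2 (within the scatter) and a number 7.2 percentage points lower from compound 2 to compound 3 (within the scatter) lie within the scatter, only a number 11 percentage points lower from compound 1 to compound 3 (beyond the scatter) goes beyond it. Compound 4 `CCN(CC)CC(O)COc1cc(OC)ccc1-c1cc(-c2ccccc2)no1` differs from compound 2 by diethylamino in place of piperidin-1-yl on a saturated chain carbon, two bonds along the chain from an oxygen on a saturated carbon. Among the measured compounds shown here, no measured step touches the amine itself; the steps seen add a hydroxy or remove the whole side chain, and those that involve compound 2 are within the scatter. The change in this assay is therefore expected to be small, a number 1 percentage points lower from compound 2 to compound 4 (within the scatter), with no direction claimed. Compound 4 is estimated at 16%, between 6% and 26%.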

Compound 4, a percentage reported as inhibition, in the whole organism at one dose (the size of the read-out at that dose, not a potency): 13.8%
Compound 4: the middle estimate sits 2.2 percentage points above what was measured; low and high end bracket the measured number.
By their numbers in this assay, from the lowest: compounds 3, 4, 2 and 1 (each within the scatter of the next, the first and the last beyond it).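

In this assay, among the compounds shown here, the first step on the amine itself, a number 3.2 percentage points lower from compound 2 to compound 4 (within the scatter), shows that diethylamino in place of piperidin-1-yl, an open amine for a ring, gives no change that can be told from the scatter at this position. Compound 4 also stays within the scatter on both sides, with a number 4 percentage points higher from compound 3 to compound 4 (within the scatter) and a number 7 percentage points lower from compound 1 to compound 4 (within the scatter), so it is not separated from compound 3 or compound 1. No supporting data bear on this result. On these data alone, whether morpholin-4-yl, dimethylamino or a longer chain to the amine would move the number beyond the scatter remains open.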